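Swapping a Pyridine for a Cyclic Sulfone

The source may report more compounds than this note shows. Statements on the series, on what has been measured and on what is new or still open speak of the compounds shown alone.

Of the compounds shown here, three built on a shared core have been tested in a functional assay on cells for agonist activity at C-X-C chemokine receptor type 4 (Homo sapiens), read by fluorescence and calcium flux, with a stated time of 90 s; a lower number here means that less compound is needed, a higher number that more compound is needed for the effect. Compound 1 `c1ccc(CN(CCCCN(C[C@H]2Cc3ccccc3CN2)[C@H]2CCCc3cccnc32)Cc2ccccn2)nc1` gives only a limit of the assay, > 30000 nM. Compound 2 `c1cncc(CN(CCCCN(C[C@H]2Cc3ccccc3CN2)[C@H]2CCCc3cccnc32)Cc2cccnc2)c1` likewise reaches only a limit, > 30000 nM. Compound 3 `c1ccc2c(c1)CN[C@@H](CN(CCCCNCc1ccncc1)[C@H]1CCCc3cccnc31)C2` also returns only a limit in this assay, > 30000 nM. Where compound 3 stands is therefore not a number but the edge of what the assay can report, and all three results sit together there (the limit of > 30000 nM in this assay, at which 3 of the 3 values shown sit).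

Compound 4 `O=S1(=O)CCC(CNCCCCN(C[C@H]2Cc3ccccc3CN2)[C@H]2CCCc3cccnc32)CC1` has not yet been measured. It differs from compound 3 in one place: 1,1-dioxothian-4-yl in place of pyridin-4-yl on a saturated chain carbon bound to an amine nitrogen. Among the compounds with values here, no measured pair of compounds shows how this kind of swap plays out, so the only guide is that compound 3 gave a limit in this assay, > 30000 nM.

With nothing pointing toward stronger activity, the step expected is a number no higher from compound 3 to compound 4 (the limit leaves the size open), that is, no change beyond the scatter. The estimate for compound 4 in this assay is 30000 nM, ranging from 10000 nM to 100000 nM.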

Compound 4, half-maximal effective concentration: > 30000 nM
Compound 4 ended at the assay's limit; the forecaster's own chance of this, stated with the estimate: 80%; the middle value lies on the limit itself.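

Within the data shown here, compound 3 and compound 4 both stop at a limit in this assay, so no step between them can be read, and all the results sit together: the limit of > 30000 nM in this assay, at which 4 of the 4 values shown sit. As far as these compounds go, what stays open is whether 1,1-dioxothian-4-yl in place of pyridin-4-yl changes activity at all.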